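The source may report more compounds than this note shows. Statements on the series, on what has been measured and on what is new or still open speak of the compounds shown alone.

Three compounds sharing one core have been measured in an assay on CHO cells for inhibition of bone morphogenetic protein 1 (Homo sapiens), with stated times of 10 min and 60 min; on this read-out lower numbers stand for stronger inhibition and higher numbers for weaker inhibition:

compound 1, `CCCCC[C@H](CN(O)C=O)C(=O)NCNC(=O)c1ccc(-c2cccc(OC)c2)o1`, 20 nM
compound 2, `CCCCC[C@H](CN(O)C=O)C(=O)NCNC(=O)c1ccc(-c2cccc(C(=O)O)c2)o1`, 8 nM
compound 3, `CCCCC[C@H](CN(O)C=O)C(=O)NCNC(=O)c1ccc(-c2ccc(C(=O)O)cc2)o1`, 1 nM

Compound 3 gives the lowest number of the three, with compound 2 nearest and compound 1 furthest. The step of a 2.5-fold lower number from compound 1 to compound 2 (0.40 log units; beyond the scatter) came with a carboxy group in place of a methoxy group. The step of an 8.0-fold lower number from compound 2 to compound 3 (0.90 log units; beyond the scatter) came with 4-carboxyphenyl in place of 3-carboxyphenyl. Together these give the step of a 20-fold lower number from compound 1 to compound 3 (1.30 log units; beyond the scatter).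

Compound 4, `CCCCC[C@H](CN(O)C=O)C(=O)NCNC(=O)c1ccc(-c2cccc(OCC)c2)o1`, has not yet been measured. It differs from compound 3 in one place: 3-ethoxyphenyl in place of 4-carboxyphenyl on an aromatic carbon. This change undoes what gave the large step of a 20-fold lower number from compound 1 to compound 3 (1.30 log units; beyond the scatter), since compound 4 differs from compound 1 only in the length of the chain on its 3-alkoxyphenyl group. Among the compounds with values here, no measured step tells how that chain matters, so the expectation rests on compound 1. In this assay compound 4 is therefore expected to give a number close to that of compound 1, a step of about a 22-fold higher number from compound 3 to compound 4 (1.34 log units; beyond the scatter) upward from compound 3. The estimate for compound 4 is 22 nM, with a range from 8 nM to 70 nM.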

Compound 4, half-maximal inhibitory concentration: 1 nM
Compound 4: middle estimate off by 22-fold (1.34 log units), on the high side, outside the stated range (below it).
By their numbers in this assay, from the lowest: compounds 3 and 4 (each within the scatter of the next); then compound 2; then compound 1.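

In this assay, the step of a 20-fold lower number from compound 1 to compound 4 (1.30 log units; beyond the scatter) shows that the alkoxy chain on the 3-alkoxyphenyl group matters a great deal here, even though the change is only methyl in place of hydrogen at the chain's end. The step of no change at the digits printed from compound 3 to compound 4 (within the scatter) shows that a carboxy group is not needed for a low number at this position of the shared core, since 3-ethoxyphenyl, with no hydrogen-bond donor, matches 4-carboxyphenyl at the digits printed, and the step of an 8.0-fold lower number from compound 2 to compound 4 (0.90 log units; beyond the scatter) shows that, among the groups on the 3-substituted phenyl ring, ethoxy goes with a lower number than carboxy, which the earlier order of carboxy below methoxy could not have suggested. Nothing available explains why so small an extension of the chain has so large an effect.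

Still open, as far as these compounds go, is whether a longer chain, such as propoxy or butoxy, would keep the low number of compound 4 or lose it. Also open, from the compounds shown here alone, is how ethoxy would behave on the phenyl ring as 4-ethoxyphenyl, the arrangement in which the carboxy group of compound 3 sits.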